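Moving a chloro group around the terminal phenyl ring

The source may hold more compounds than are shown below. What is called first, only, known or untested is meant among the compounds shown, and "the series" means these compounds.

Of the compounds shown here, three sharing one core have been tested in an ADME assay on MT4 cells (Homo sapiens) for cytotoxicity, read by MTT assay, with a stated time of 4 days; on this read-out higher numbers stand for lower toxicity in this test and lower numbers for higher toxicity in this test. Compound 1, `Cc1cc(-c2ccccc2)cc(C)c1Nc1ccnc(Nc2ccc(C#N)cc2)n1`, gives 4170 nM in this assay. Compound 2, `Cc1cc(-c2cccc(C#N)c2)cc(C)c1Nc1ccnc(Nc2ccc(C#N)cc2)n1`, gives 920 nM. Compound 3, `Cc1cc(-c2ccc(Cl)cc2)cc(C)c1Nc1ccnc(Nc2ccc(C#N)cc2)n1`, gives 4190 nM. Among these three numbers compound 1 stands second highest: compound 3 sits at a 1.0-fold higher number from compound 1 to compound 3 (0.00 log units; within the scatter), which is within the scatter, while compound 2 sits at a 4.5-fold lower number from compound 1 to compound 2 (0.66 log units; beyond the scatter), a step beyond the scatter toward higher toxicity.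

The unmeasured compound 4, `Cc1cc(-c2ccccc2Cl)cc(C)c1Nc1ccnc(Nc2ccc(C#N)cc2)n1`, differs from compound 1 by chloro in place of hydrogen on an aromatic carbon placed ortho to a large group on the outer ring. For the measured compounds named here, the step that bears most directly on this is the one from compound 1 to compound 3, where the same kind of change, chloro in place of hydrogen on an aromatic carbon, was made at another place on that ring and moved the number by a 1.0-fold higher number from compound 1 to compound 3 (0.00 log units; within the scatter), within the scatter. Going by the values given here, the only change that moved the number beyond the scatter was a cyano group, as in compound 2, not a chloro group. The expected step from compound 1 to compound 4 is therefore a 1.0-fold lower number from compound 1 to compound 4 (0.02 log units; within the scatter), no change beyond the scatter. Compound 4 is estimated at 4000 nM, with a range from 1600 nM to 10000 nM.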

Compound 4, half-maximal cytotoxic concentration: 3990 nM
Estimate against measurement, compound 4: 1.0-fold (0.00 log units) above; measured number inside the range.
By their numbers in this assay, from the lowest: compound 2; then compounds 4, 1 and 3 (each within the scatter of the next).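

In this assay a chloro group on an aromatic carbon ortho to a large group leaves the number within the scatter, as a 1.0-fold lower number from compound 1 to compound 4 (0.02 log units; within the scatter) shows. Chloro had been seen at only one place on the outer ring, and comparing that place with this new one gives a 1.1-fold lower number from compound 3 to compound 4 (0.02 log units; within the scatter), so for these compounds the choice between 2-chlorophenyl and 4-chlorophenyl makes no difference beyond the scatter. The 3-cyanophenyl compound remains the one that stands apart, with a 4.3-fold higher number from compound 2 to compound 4 (0.64 log units; beyond the scatter), so the second chloro compound shows that a change beyond the scatter does not follow from simply adding a group to this ring.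

Nothing measured here offers a reason for these results. Going by these compounds, whether compound 2 stands apart for the cyano group itself or for its place on the ring remains open, as does what an amine or a carboxylic acid on the outer ring would give.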